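Bromine Added to the Dimethoxy-Substituted Ring

The source may hold more compounds than are shown below. What is called first, only, known or untested is meant among the compounds shown, and "the series" means these compounds.

Of the compounds shown here, three sharing one core have been measured in an assay for inhibition of Alpha amylase (Homo sapiens), with a stated time of 10 min; a higher number here means a weaker inhibitor, a lower number a stronger inhibitor. Compound 1 `COc1ccccc1/C=C1/C(=O)N(c2ccc(Cl)cc2)N=C1C` gives 2020 nM. Compound 2 `COc1ccc(OC)c(/C=C2/C(=O)N(c3ccc(Cl)cc3)N=C2C)c1` gives 2130 nM, and compound 3 `COc1ccc(/C=C2/C(=O)N(c3ccc(Cl)cc3)N=C2C)cc1OC` gives 2030 nM. Compound 2 holds the highest of these three numbers, yet its distance to compound 3 and to compound 1 is within the scatter, so no order among the three can be read from them. Among the compounds with values here, the only single-point step available is a 1.1-fold higher number from compound 1 to compound 2 (0.02 log units; within the scatter).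

Compound 4 `COc1cc(/C=C2/C(=O)N(c3ccc(Cl)cc3)N=C2C)c(OC)cc1Br` differs from compound 2 by bromo in place of hydrogen on an aromatic carbon. Within the data shown here, no measured step involves a bromo group, so the change to compound 4 has no direct precedent. Among the measured compounds shown here, the one step that is known, the methoxy addition that produced compound 2, moved this assay's number by an amount within the scatter, and that is the nearest evidence that adding a substituent to this ring leaves the read-out largely where it was. On that basis the expected step is a 1.1-fold lower number from compound 2 to compound 4 (0.03 log units; within the scatter), none beyond the scatter. Compound 4 is therefore estimated to give 2000 nM in this assay, with a range from 900 nM to 4500 nM.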

Compound 4, half-maximal inhibitory concentration: 1860 nM
The estimate for compound 4 lay 1.1-fold (0.03 log units) above the measured number, within the range that was stated.
By their numbers in this assay, from the lowest: compounds 4, 1, 3 and 2 (each within the scatter of the next).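

In this assay, the step of a 1.1-fold lower number from compound 2 to compound 4 (0.06 log units; within the scatter) is all that bromo brings at this place, on an aromatic carbon ortho to a methoxy group, meta to a methoxy group and para to a large group. Before compound 4, the only step that could be read on this ring was the methoxy step, so the new result extends the picture from one kind of substituent to a second: a hydrogen can give way to a single bromine atom on the ring of compound 2 with no difference that can be told from the scatter. No measurement at hand bears on why the number stays within the scatter of that of compound 2.

The four compounds leave open whether this position stays as undemanding with a group of another kind, such as an amine, a carboxylic acid or a longer chain in place of bromo. They also leave open whether any change at this place can move the number beyond the scatter, since every compound shown so far lies within the scatter of the next.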